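The source may hold more compounds than are shown below. What is called first, only, known or untested is meant among the compounds shown, and "the series" means these compounds.

Working notes on the series

The series is followed in a functional assay on U-937 cells (Homo sapiens) for antiproliferative activity, read by MTT assay, with a stated time of 24 h; a lower number here means a stronger inhibitor, a higher number a weaker inhibitor. Compound 1 `CNC(=O)c1ccccc1Oc1nc(Nc2ccccc2F)ncc1Br` sets the frame: in this assay compound 1 gives > 50000 nM, which is a limit of the assay and not a number. Compound 2 `CNC(=O)c1ccccc1Oc1nc(Nc2cccc(C(F)(F)F)c2)ncc1Br` carries a trifluoromethyl on the aniline ring in place of the fluorine of compound 1; in this assay compound 2 gives 45500 nM. Within the data shown here, this is the only number in hand for the series, the other value being the limit (the limit of > 50000 nM in this assay, at which 1 of the 2 values shown sits), so compound 2 cannot be placed above or below any other measured compound; it stands as a weak inhibitor.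

Compound 3 `CNC(=O)c1ccccc1Oc1nc(Nc2cccc(C(C)C)c2)ncc1Br` is the next step from compound 2: isopropyl in place of trifluoromethyl on an aromatic carbon. Among the measured compounds shown here, no measured step of this kind exists, so no direction can be read from the data. With only the weak number of compound 2 45500 nM to rest on, a step from compound 2 to compound 3 of a 1.1-fold lower number from compound 2 to compound 3 (0.06 log units; within the scatter) is expected, not beyond the scatter in either direction. Compound 3 is thus estimated at 40000 nM in this assay, within 15000 nM to 150000 nM, with a fair chance that only a limit is reported.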

Compound 3, half-maximal inhibitory concentration: 14100 nM
For compound 3 the middle estimate is 2.8-fold (0.45 log units) above the measured one; the whole stated range lies above it.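

In this assay, isopropyl in place of trifluoromethyl on an aromatic carbon, meta to a large group, gives a 3.2-fold lower number from compound 2 to compound 3 (0.51 log units; beyond the scatter), so this position responds to the group it carries, although compound 3 at 14100 nM remains a weak inhibitor. Among these compounds, this is the first step that joins two numbers and so has a measured size, whereas the earlier pair offered only one number and a limit. The comparison with the other end of the series, 3-isopropylphenyl in place of 2-fluorophenyl on a nitrogen on an aromatic ring, gives an at least 3.5-fold lower number from compound 1 to compound 3 (0.54 log units; beyond the scatter), and this step is only a bound since compound 1 stands at a limit of the assay: the limit of > 50000 nM in this assay, at which 1 of the 3 values shown sits.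

On these data alone, two groups at one position give no trend, so what a methoxy group, an amine or a longer alkyl chain on the same aromatic carbon would give stays open. Also open, as far as these compounds go, is whether isopropyl on another carbon of that ring would keep the lower number seen for compound 3, and whether any change away from this ring would move the read-out at all.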